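This account rests on a few compounds, and the source may have more. Where it says the series, first, only, none or still open, it means among the compounds named here.

In a functional assay on the whole organism (strain albino) for inhibition, with Rattus norvegicus as the target, read by paw edema, with a stated time of 5 h, at a dose of 0.28 mmol/kg by the oral route (a lower number here means less inhibition, a higher number more inhibition at the dose given (going by the name of the read-out)), compound 3 `C=CCn1c(SCC(=O)c2ccccc2)nnc1-c1ccc(OC)cc1` gives 61%. Compound 1 `CCn1c(SCC(=O)c2ccccc2)nnc1-c1ccc(OC)cc1` gives 61% in this assay, and compound 2 `COc1ccc(-c2nnc(SCC(=O)c3ccccc3)n2-c2ccccc2)cc1OC` gives 59%. Compound 3 thus stands level with compound 1, and the number for compound 2 lies within the scatter of both, so the three measured compounds cannot be told apart. For the measured compounds named here, the one measured step that changes a single place, no change at the digits printed from compound 1 to compound 3 (within the scatter), shows that swapping a small group on the chain attached to the ring nitrogen left the read-out unchanged.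

Compound 4 `COc1ccc(-c2nnc(SCC(=O)c3ccccc3)n2-c2ccccc2)cc1` differs from compound 3 by phenyl in place of allyl on an aromatic nitrogen. Going by the values given here, no measured step tries this exchange, so its effect is unknown; compound 2 also carries a phenyl on an aromatic nitrogen of the core, but it bears an extra methoxy group as well, so only its value can be noted, and that value sits in the same band. The step from compound 3 to compound 4 is therefore expected to be a number 1 percentage points lower from compound 3 to compound 4 (within the scatter), with no change beyond the scatter. Compound 4 is estimated at 60%, within a range from 50% to 70%.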

Compound 4, a percentage reported as inhibition, in the whole organism at one dose (the size of the read-out at that dose, not a potency): 61%
Estimate against measurement, compound 4: 1 percentage points below, within the range that was stated.
By their numbers in this assay, from the lowest: compounds 2, 1, 3 and 4 (each within the scatter of the next).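

Replacing allyl with phenyl on the aromatic nitrogen brings in a six-membered aromatic ring in place of a three-carbon chain, yet this assay shows (no change at the digits printed from compound 3 to compound 4 (within the scatter)), and phenyl in place of ethyl at the same nitrogen likewise shows (no change at the digits printed from compound 1 to compound 4 (within the scatter)). So among ethyl, allyl and phenyl, this nitrogen has shown no sensitivity to the size or ring character of its group in this read-out. The methoxyphenyl group gives a second reading, with hydrogen in place of methoxy on an aromatic carbon showing (a number 2 percentage points higher from compound 2 to compound 4 (within the scatter)), so the extra methoxy group makes no difference that can be read here. Nothing available explains why the read-out stays this flat.

From the compounds shown here alone, it remains open whether a group of another kind on this nitrogen, such as a chain ending in an amine or a carboxylic acid, would move the number. A single dose also leaves open whether these compounds differ at lower doses.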